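Replacing furan-3-yl with 3-methoxyphenyl on a GPR88 agonist

The source may hold more compounds than are shown below. What is called first, only, known or untested is meant among the compounds shown, and "the series" means these compounds.

Compound 1 `CC[C@H](C)[C@@H](CN(C(=O)[C@@H]1C[C@H]1c1ccccc1)c1ccc(-c2ccccc2)cc1)NC(C)=O`: 5.8 nM
Compound 2 `CC(C)C[C@H](N)CN(C(=O)[C@@H]1C[C@H]1c1ccccc1)c1ccc(-c2ccoc2)cc1`: 2000 nM

In a functional assay for agonist activity at G protein-coupled receptor 88 (Homo sapiens), read by HTRF and cAMP accumulation (a higher number here means that more compound is needed for the effect, a lower number that less compound is needed), compound 1 gives 5.8 nM, while compound 2 gives 2000 nM, the highest of the two numbers and well beyond the scatter from compound 1. Compound 2 and compound 1 differ in several places, so no single change explains the gap. Compound 3 `COc1cccc(-c2ccc(N(C[C@@H](N)CC(C)C)C(=O)[C@@H]3C[C@H]3c3ccccc3)cc2)c1` keeps the core of compound 2 and changes one group: 3-methoxyphenyl in place of furan-3-yl on an aromatic carbon. Compound 1 carries a six-membered carbon ring at the same place, which makes a lower number expected for compound 3, a step of a 6.7-fold lower number from compound 2 to compound 3 (0.82 log units; beyond the scatter) beyond the scatter. Compound 3 is estimated at 300 nM (range 60 nM to 1500 nM).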

Compound 3, half-maximal effective concentration: 1100 nM
The estimate for compound 3 lay 3.7-fold (0.56 log units) below the measured number; measured number inside the range.
By their numbers in this assay, from the lowest: compound 1; then compounds 3 and 2 (each within the scatter of the next).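

On an aromatic carbon para to a large group, 3-methoxyphenyl in place of furan-3-yl gives, in this assay, a 1.8-fold lower number from compound 2 to compound 3 (0.26 log units; within the scatter), so this change stays within the scatter. On this core, exchanging the five-membered ring for a six-membered ring of carbon only therefore does not by itself reach the number of compound 1 at 5.8 nM. No data given here bear on why the step is so small.

Going by these compounds, it remains open whether a nitrile on this ring, or a pyridine ring at this place, would move the number beyond the scatter. On these data alone, it is also open what an acetamide in place of the amine would do on this core.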